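This account rests on a few compounds, and the source may have more. Where it says the series, first, only, none or still open, it means among the compounds named here.

Measured compounds in a physicochemical assay for solubility, read by HPLC; on this read-out lower numbers stand for lower solubility and higher numbers for higher solubility:
Compound 1, `COc1ccc(NC[C@@H](O)COc2ccc(N3C[C@H](CNC(C)=O)OC3=O)cc2F)cc1`: 1300 nM
Compound 2, `CC(=O)NC[C@H]1CN(c2ccc(OC[C@@H](O)CNc3ccccn3)c(F)c2)C(=O)O1`: 22200000 nM
Compound 3, `CC(=O)NC[C@H]1CN(c2ccc(OC[C@@H](O)CNc3cccnc3)c(F)c2)C(=O)O1`: 3040000 nM

Among these three, compound 3 stands second highest. Among the compounds with values here, its nearest neighbour is compound 2: the step of a 7.3-fold lower number from compound 2 to compound 3 (0.86 log units; beyond the scatter) is the only single-point change measured here, swapping pyridin-3-yl for pyridin-2-yl on an amine nitrogen. Within the data shown here, compound 1 lies far below compound 3, as its value shows, but the two differ in more than one place, so no single step is drawn between them.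

Compound 4, `CC(=O)NC[C@H]1CN(c2ccc(OC[C@H](O)CNc3cccnc3)c(F)c2)C(=O)O1`, has not yet been measured. Compared with compound 3, (the two compounds have the same atoms and bonds and differ only in configuration as drawn: 1 of 2 stereo elements differ; a stereocentre at a saturated chain carbon is drawn S in compound 3 and R in compound 4). Among the measured compounds shown here, none of the measured steps involves a change of configuration alone, so there is no precedent here to set the size or direction of this move. Without such a precedent, the expectation is a step of a 1.0-fold lower number from compound 3 to compound 4 (0.01 log units; within the scatter), that is, nothing clearly beyond the scatter. Compound 4 is therefore estimated at 3000000 nM, with a range from 1000000 nM to 9000000 nM.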

Compound 4, solubility: 10100000 nM
Estimate against measurement, compound 4: 3.4-fold (0.53 log units) below; the measured number lies above the stated range.
By their numbers in this assay, from the lowest: compound 1; then compound 3; then compound 4; then compound 2.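

In this assay, within the data shown here, the result is a 3.3-fold higher number from compound 3 to compound 4 (0.52 log units; beyond the scatter); this is the first sign that configuration at this saturated chain carbon can shift the number on its own, and the step can be placed there alone: the fact that compounds 3 and 4 differ only in the configuration as drawn. With 1-hydroxy-2-((pyridin-3-yl)amino)ethyl in place of 1-hydroxy-2-((pyridin-2-yl)amino)ethyl, the reading is a 2.2-fold lower number from compound 2 to compound 4 (0.34 log units; beyond the scatter), so the pyridin-2-yl compound still stands above, although this step carries both the ring change and the configuration. Pyridin-3-yl in place of 4-methoxyphenyl on the amine nitrogen gives a 7800-fold higher number from compound 1 to compound 4 (3.89 log units; beyond the scatter), which remains far larger than the configuration step.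

The compounds shown leave open whether configuration moves the number the same way with pyridin-2-yl or 4-methoxyphenyl on that nitrogen. They also leave open what a methoxy group or an amine in place of the hydroxy group on the chain would do.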